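A few compounds are considered here, and "the series" means these few. Any claim that something is new, unique, unknown or untested is made for them only; others in the source may bear on it.

Measured compounds in a functional assay on MCF7 cells (Homo sapiens) for inhibition, read by MTT assay, with a stated time of 72 h; on this read-out lower numbers stand for stronger inhibition and higher numbers for weaker inhibition:
compound 1 `COc1ccc(N2CCN(C(=S)N/N=C3\C(=O)Nc4ccc(Cl)cc43)CC2)cc1`: 13800 nM
compound 2 `Cc1ccccc1N1CCN(C(=S)N/N=C2\C(=O)Nc3ccc(Cl)cc32)CC1`: 10900 nM
compound 3 `O=C1Nc2ccc(Cl)cc2/C1=N/NC(=S)N1CCN(c2ccc(F)cc2F)CC1`: 20100 nM

Compound 3 gives the highest of the three numbers, but a 1.5-fold higher number from compound 1 to compound 3 (0.16 log units; within the scatter) and a 1.8-fold higher number from compound 2 to compound 3 (0.27 log units; within the scatter) both lie within the scatter, as does a 1.3-fold lower number from compound 1 to compound 2 (0.10 log units; within the scatter); on this read-out the three compounds cannot be told apart.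

Compound 4 `O=C1Nc2ccc(Cl)cc2/C1=N/NC(=S)N1CCN(c2ccc([N+](=O)[O-])cc2)CC1` differs from compound 3 only at the aryl group on the ring nitrogen: 4-nitrophenyl in place of 2,4-difluorophenyl on an amine nitrogen in a ring. The three measured steps all exchange one aryl group for another at this same position, and none of them moves the number beyond the scatter. Among the compounds with values here, no step involving a nitro-bearing aryl group has been measured, so the new group itself has no precedent here. With every measured change at this position silent, no shift beyond the scatter is expected in this assay either, and a 1.3-fold lower number from compound 3 to compound 4 (0.13 log units; within the scatter) is taken as an expected step of no real size.

For compound 4 the expected value in this assay is 15000 nM, with a range of 5000 nM to 45000 nM.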

Compound 4, half-maximal inhibitory concentration: 20900 nM
For compound 4 the middle estimate is 1.4-fold (0.14 log units) below the measured one, within the range that was stated.
By their numbers in this assay, from the lowest: compounds 2, 1, 3 and 4 (each within the scatter of the next).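

In this assay a nitro-bearing aryl group on the amine nitrogen in a ring proves as silent as the others, with a 1.0-fold higher number from compound 3 to compound 4 (0.02 log units; within the scatter) and a 1.9-fold higher number from compound 2 to compound 4 (0.28 log units; within the scatter) and a 1.5-fold higher number from compound 1 to compound 4 (0.18 log units; within the scatter) all inside the scatter. The 2 hydrogen-bond acceptors and the double bond outside aromatic rings that enter with 4-nitrophenyl come with no measurable shift against 2,4-difluorophenyl, so the four aryl groups on compound 1, compound 2, compound 3 and compound 4 cannot be told apart on this read-out. Nothing available explains why these exchanges leave the number unmoved.

Still open, on these data alone, is whether a group of another kind on this nitrogen, such as a benzyl group, a longer alkyl chain or a carboxylic acid, would move the number beyond the scatter. Changes to the shared core itself, such as replacing the chlorine or the thiocarbonyl, also remain untested in the compounds shown.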